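This account rests on a few compounds, and the source may have more. Where it says the series, first, only, none or still open, it means among the compounds named here.

Measured so far in a functional assay on SGC-7901 cells (Homo sapiens) for antiproliferative activity, read by MTT assay, with a stated time of 24 h; a lower number here means a stronger inhibitor, a higher number a weaker inhibitor:
compound 1 `Cc1ccc(-n2cc(-c3ccccc3NS(=O)(=O)c3c[nH]c(=O)[nH]c3=O)nn2)cc1`: 6390 nM
compound 2 `O=c1[nH]cc(S(=O)(=O)Nc2ccccc2-c2cn(-c3ccc(F)cc3)nn2)c(=O)[nH]1`: a limit, > 20000 nM
compound 3 `O=c1[nH]cc(S(=O)(=O)Nc2ccccc2-c2cn(-c3cccc(Cl)c3)nn2)c(=O)[nH]1`: 2270 nM

Compound 3 stands lowest of the two numbers; the step of a 2.8-fold lower number from compound 1 to compound 3 (0.45 log units; beyond the scatter) separates it from compound 1. The value of compound 2 is a limit of this assay, not a number (the limit of > 20000 nM in this assay, at which 1 of the 3 values shown sits).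

Compound 4 `O=c1[nH]cc(S(=O)(=O)Nc2ccccc2-c2cn(-c3ccc(Cl)cc3)nn2)c(=O)[nH]1` differs from compound 3 by 4-chlorophenyl in place of 3-chlorophenyl on an aromatic nitrogen. For the measured compounds named here, no measured step moves a chlorine alone. Both aryl groups bearing a group in the 4-position of the phenyl, in compound 1 and compound 2, gave higher numbers than the 3-chlorophenyl of compound 3: a 2.8-fold lower number from compound 1 to compound 3 (0.45 log units; beyond the scatter) and an at least 8.8-fold lower number from compound 2 to compound 3 (0.94 log units; beyond the scatter), while an at least 3.1-fold higher number from compound 1 to compound 2 (0.49 log units; beyond the scatter) shows that the identity of that group also matters. A modest rise is therefore expected in this assay, a 2.4-fold higher number from compound 3 to compound 4 (0.38 log units; beyond the scatter). Compound 4 is estimated at 5500 nM, range 2000 nM to 16000 nM.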

Compound 4, half-maximal inhibitory concentration: 2700 nM
Compound 4: middle estimate off by 2.0-fold (0.31 log units), on the high side; low and high end bracket the measured number.
By their numbers in this assay, from the lowest: compounds 3 and 4 (each within the scatter of the next); then compound 1. At a limit, above all of these: compound 2.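

In this assay the 3-chlorophenyl and 4-chlorophenyl groups on the aromatic nitrogen cannot be told apart, a 1.2-fold higher number from compound 3 to compound 4 (0.08 log units; within the scatter), so the 4-chlorophenyl group does not share the higher numbers of compound 1 and compound 2. The group on the phenyl carbon therefore matters, with a 2.4-fold lower number from compound 1 to compound 4 (0.37 log units; beyond the scatter) for chloro in place of methyl and an at least 7.4-fold lower number from compound 2 to compound 4 (0.86 log units; beyond the scatter) for chloro in place of fluoro. The value of compound 2 is a limit, not a number: the limit of > 20000 nM in this assay, at which 1 of the 4 values shown sits.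

From the compounds shown here alone, whether a bromo, methoxy or amine group on that phenyl would behave like chloro remains open. So does the standing of 3-methylphenyl and 3-fluorophenyl against their 4-substituted counterparts.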